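This account rests on a few compounds, and the source may have more. Where it says the series, first, only, none or still open, it means among the compounds named here.

Measured so far:
compound 1 `CC1=CC[C@@H]([C@@](C)(O)CCCC(C)(C)NC(=S)N/N=C\c2ccc(C)cc2)CC1` with 45700 nM
compound 2 `CC1=CC[C@@H]([C@@](C)(O)CCCC(C)(C)NC(=S)N/N=C\c2ccc(O)cc2)CC1` with 13900 nM

In a functional assay on PCO3 cells (Homo sapiens) for cytotoxicity, read by sulforhodamine B assay (on this read-out lower numbers stand for stronger inhibition of growth and higher numbers for weaker inhibition of growth), compound 1 gives the higher of the two numbers, and compound 2 gives the lower one; that step is a 3.3-fold lower number from compound 1 to compound 2 (0.52 log units; beyond the scatter). Compound 3 `CC1=CC[C@@H]([C@@](C)(O)CCCC(C)(C)NC(=S)N/N=C\c2ccc(N(C)C)cc2)CC1` has not been measured. It differs from compound 1 by dimethylamino in place of methyl on an aromatic carbon. Within the data shown here, only one measured step bears on this change: the one from compound 1 to compound 2, which also swaps the methyl on that same aromatic carbon for another group and gave a 3.3-fold lower number from compound 1 to compound 2 (0.52 log units; beyond the scatter), a modest lowering beyond the scatter. Among the measured compounds shown here, the group entering in compound 3 is not the one entering in compound 2, so that step is a guide, not a rule. For compound 3 a lowering of roughly that size is expected, as a 2.3-fold lower number from compound 1 to compound 3 (0.36 log units; beyond the scatter). The estimate for compound 3 in this assay is 20000 nM, with a range from 8000 nM to 60000 nM.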

Compound 3, concentration for total growth inhibition: > 100000 nM
Compound 3 ended at the assay's limit (the forecaster's own chance of this, stated with the estimate: 5%); middle value at least 5.0-fold (0.69 log units) from the limit.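

In this assay compound 3 stands at a limit of the assay, > 100000 nM, and this is not a measured number. Even so, the direction can be read: dimethylamino on this aromatic carbon, para to a large group, gives an at least 2.1-fold higher number from compound 1 to compound 3 (0.34 log units; beyond the scatter), and replacing hydroxy with it gives an at least 7.1-fold higher number from compound 2 to compound 3 (0.85 log units; beyond the scatter). The position therefore does not respond the same way to every replacement of methyl, since hydroxy lowered the number and dimethylamino raised it, though these steps give only a minimum size: the limit of > 100000 nM in this assay, at which 1 of the 3 values shown sits.

From the compounds shown here alone, it remains open what an unsubstituted amino group, a methoxy group or a chlorine atom would do on this carbon. Three groups on one shared core are too few to show whether the hydroxy or the dimethylamino result is the exception.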